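Notes on the amine substituent at the shared core

A few compounds are considered here, and "the series" means these few. Any claim that something is new, unique, unknown or untested is made for them only; others in the source may bear on it.

Measured so far:
compound 1 `CCCCCCCCNc1nc(SCc2ccc(C(F)(F)F)cc2)nc2ccccc12` gives 22300 nM in a functional assay on MDA-MB-231 cells (Homo sapiens) for cytotoxicity, read by MTT assay, with a stated time of 72 h; on this read-out lower numbers stand for stronger inhibition and higher numbers for weaker inhibition.
compound 2 `COc1ccccc1Nc1nc(SCc2ccc(C(F)(F)F)cc2)nc2ccccc12` reaches only the assay limit > 50000 nM, a limit and not a number.
compound 3 `O=[N+]([O-])c1ccc(Nc2nc(SCc3ccc(C(F)(F)F)cc3)nc3ccccc23)cc1` gives 8670 nM.
compound 4 `FC(F)(F)c1ccc(CSc2nc(Nc3ccc(C(F)(F)F)cc3)c3ccccc3n2)cc1` is not yet measured.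

Compound 3 holds the lowest of the two numbers shown; the nearest is compound 1, with a 2.6-fold lower number from compound 1 to compound 3 (0.41 log units; beyond the scatter). Against compound 2 the step is an at least 5.7-fold lower number from compound 2 to compound 3 (0.76 log units; beyond the scatter), bounded by the limit of > 50000 nM in this assay, at which 1 of the 3 values shown sits. Both steps point the same way: the aryl amine of compound 3 sits below the octyl amine and well below the 2-methoxyphenyl amine.

Compound 4 keeps the aryl amine of compound 3 and changes only its substituent: trifluoromethyl in place of nitro on an aromatic carbon. Within the data shown here, no measured step covers this swap directly; the two steps into compound 3 speak only to the aryl group as a whole. The expectation is therefore a small loss, a 1.7-fold higher number from compound 3 to compound 4 (0.24 log units; within the scatter), not beyond the scatter with confidence. Compound 4 is estimated at 15000 nM, within 5000 nM to 45000 nM.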

Compound 4, half-maximal inhibitory concentration: 5460 nM
Compound 4: the middle estimate sits 2.7-fold (0.44 log units) above what was measured, and the stated range covers the measured number.
By their numbers in this assay, from the lowest: compounds 4 and 3 (each within the scatter of the next); then compound 1. At a limit, above all of these: compound 2.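

In this assay, trifluoromethyl in place of nitro gives a 1.6-fold lower number from compound 3 to compound 4 (0.20 log units; within the scatter), so the nitro group is not required for the level seen with compound 3, and a group with no hydrogen-bond acceptors gives a reading within the scatter of it. A second para-substituted aryl amine also separates from the octyl amine, with a 4.1-fold lower number from compound 1 to compound 4 (0.61 log units; beyond the scatter). Against the 2-methoxyphenyl amine the step is an at least 9.1-fold lower number from compound 2 to compound 4 (0.96 log units; beyond the scatter), and compound 2 stands at a limit, not a number: the limit of > 50000 nM in this assay, at which 1 of the 4 values shown sits.

From the compounds shown here alone, it remains open how an amine or a carboxylic acid at the same place on the phenyl ring would read. The compounds shown also leave open whether the limit of compound 2 goes with the methoxy group itself or with where it sits on the ring.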